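From chloro to dimethylamino on a weak inhibitor

The source may hold more compounds than are shown below. What is called first, only, known or untested is meant among the compounds shown, and "the series" means these compounds.

Compound 1 `O=C1CCCCC/C1=C\c1cccc(F)c1`: > 50000 nM (a limit, not a number)
Compound 2 `O=C1CCCCC/C1=C\c1ccc(Cl)cc1`: 19100 nM

Both compounds were tested in a functional assay on P388 cells (Mus musculus) for inhibition; a lower number here means a stronger inhibitor, a higher number a weaker inhibitor. Among the compounds with values here, compound 2, at 19100 nM, gives the only exact number so far. The result for compound 1 is only a limit. This single number offers a starting point, but it does not show a trend.

The next compound is compound 3 `CN(C)c1ccc(/C=C2\CCCCCC2=O)cc1`. It has dimethylamino in place of chloro on an aromatic carbon, para to a group of 9 heavy atoms: dimethylamino in place of chloro on an aromatic carbon. Within the data shown here, no pair of measured compounds differs in just one place, so the data contain no comparable change from which to judge its size or direction. The working expectation in this assay is therefore no step beyond the scatter, in either direction, with compound 2 at 19100 nM as the anchor. The estimated change is a 1.0-fold higher number from compound 2 to compound 3 (0.02 log units; within the scatter). This uncertainty calls for a wide range. For compound 3, the expected value is 20000 nM, with an estimated range from 6000 nM to 50000 nM.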

Compound 3, half-maximal inhibitory concentration: 18800 nM
Beside the measured number, compound 3's estimate is 1.1-fold (0.03 log units) above it; low and high end bracket the measured number.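

Within the data shown here, this is the first step in this assay that can be read: placing dimethylamino instead of chloro on the aromatic carbon, para to a group of 9 heavy atoms, gives a 1.0-fold lower number from compound 2 to compound 3 (0.01 log units; within the scatter). The entering group has 3 heavy atoms where the leaving group has 1, and it adds 1 hydrogen-bond acceptor, yet compound 2 and compound 3 cannot be told apart in this read-out, so at this position the exchange leaves the compound a weak inhibitor. That reading has a boundary, because a much weaker compound would no longer give an exact number: the limit of > 50000 nM in this assay, at which 1 of the 3 values shown sits.

The compounds shown leave open whether a very different group at this same place, such as a carboxylic acid or a longer chain, would bring the number clearly down or push it up. A single step also reveals nothing about changes elsewhere on the shared core, so it cannot show whether this position is generally tolerant or whether these two groups simply happen to give matching results.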